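The compounds below may be only part of what the source reports. "The series", "measured", "known", "first", "only" and "open" are said of these compounds alone.

Compound 1 `CCCNC(=O)OC(CC1CC[N+]2(CCCC2)CC1)CC1CC[N+]2(CCCC2)CC1` is one of a pair of bis-quaternary compounds tested in a functional assay on the whole organism with Mus musculus as the target, in the writhing test, at a dose of 0.04 mmol/kg by the subcutaneous route; on this read-out lower numbers stand for less inhibition and higher numbers for more inhibition at the one dose given (going by the name of the read-out); compound 1 gives 70.9%, the higher of the two numbers. Compound 2 `CCCCCCCCCCCNC(=O)OC(CC1CC[N+]2(CCCC2)CC1)CC1CC[N+]2(CCCC2)CC1` differs from it only by a longer chain on the carbamate nitrogen, and in this assay compound 2 gives 39%, a step of a number 31.9 percentage points lower from compound 1 to compound 2 (beyond the scatter).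

Compound 3 `OC(CC1CC[N+]2(CCCC2)CC1)CC1CC[N+]2(CCCC2)CC1` has not yet been measured. It differs from compound 1 by hydrogen in place of propylcarbamoyl on an oxygen on a saturated carbon. For the measured compounds named here, no measured step repeats this change: the only step known alters the chain carried by the carbamate, whereas here the whole carbamate is lost, leaving the shared core with a free hydroxy. That single step shows the carbamate region matters, so a shift is plausible, but its direction is not fixed by the data. The expected number for compound 3 is therefore 50%, within a range of 20% to 80%, an estimated step of a number 20.9 percentage points lower from compound 1 to compound 3 (beyond the scatter).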

Compound 3, a percentage reported as inhibition, in the whole organism at one dose (the size of the read-out at that dose, not a potency): 88.9%
The estimate for compound 3 lay 38.9 percentage points below the measured number; measured number outside the range, above it.
By their numbers in this assay, from the lowest: compound 2; then compound 1; then compound 3.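

In this assay the exchange of (propylcarbamoyl)oxy for hydroxy gives a number 18 percentage points higher from compound 1 to compound 3 (beyond the scatter) and so the shared core with a free hydroxy needs no carbamate to reach a high number at this dose. The earlier step, a number 31.9 percentage points lower from compound 1 to compound 2 (beyond the scatter) and nothing more, concerned only the chain on the carbamate nitrogen, so it could not show what the carbamate as a whole contributes at this oxygen. No measurement at hand explains why the number rises with this change.

The compounds shown leave open whether an acetyl or a methyl on this oxygen would keep the number as high as the free hydroxy does, and whether an amine in place of the hydroxy would do the same. They also leave open how a butyl or a hexyl on the carbamate nitrogen would read.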